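The source may report more compounds than this note shows. Statements on the series, on what has been measured and on what is new or still open speak of the compounds shown alone.

Compound 1, `COc1cc(C(c2ccc(O)c(OC)c2)[C@@H](C)[C@H](C)CO)ccc1O`: in a functional assay on HL-60 cells (Homo sapiens) for cytotoxicity, read by WST assay, with a stated time of 48 h (on this read-out higher numbers stand for weaker inhibition and lower numbers for stronger inhibition), compound 1 gives only a limit, > 100000 nM.
Compound 2, `COc1cc(C(c2ccc(O)c(OC)c2)[C@H](C)[C@@H](C)CF)ccc1O`: compound 2 gives 45000 nM.
Compound 3, `COc1cc(C(c2ccc(O)c(OC)c2)[C@H](C)C(C)C)ccc1O`: compound 3 gives 17000 nM.

Compound 3 has the lowest number shown; compound 2 sits higher by a 2.6-fold lower number from compound 2 to compound 3 (0.42 log units; beyond the scatter). The value of compound 1 is a limit, (the limit of > 100000 nM in this assay, at which 1 of the 3 values shown sits). Compound 4, `CCCCCCCC[C@H](C(C)C)C(c1ccc(O)c(OC)c1)c1ccc(O)c(OC)c1`, differs from compound 3 by heptyl in place of hydrogen on a saturated chain carbon, three bonds along the chain from two aromatic carbons. Within the data shown here, no measured step adds a chain of this kind; the nearest, a 2.6-fold lower number from compound 2 to compound 3 (0.42 log units; beyond the scatter) and an at least 5.8-fold lower number from compound 1 to compound 3 (0.76 log units; beyond the scatter), change the group on the same saturated carbon and were modest. Compound 4 is therefore expected to move by a 2.1-fold lower number from compound 3 to compound 4 (0.33 log units; beyond the scatter), a modest step toward a lower number, with wide uncertainty. The estimate for compound 4 is 8000 nM, between 2000 nM and 40000 nM.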

Compound 4, half-maximal inhibitory concentration: 3700 nM
Compound 4: middle estimate off by 2.2-fold (0.33 log units), on the high side; measured number inside the range.
By their numbers in this assay, from the lowest: compound 4; then compound 3; then compound 2. At a limit, above all of these: compound 1.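

The earlier steps shown here only exchanged groups at the end of the side chain. This one shows that, on the saturated chain carbon three bonds along the chain from two aromatic carbons, a large addition such as heptyl still lowers the number in this assay: a 4.6-fold lower number from compound 3 to compound 4 (0.66 log units; beyond the scatter). Nothing measured here gives a reason for this step.

From the compounds shown here alone, it remains open whether a shorter chain such as butyl, a longer chain such as dodecyl, or a chain ending in an amine would lower the number further. Also open, going by these compounds, is whether heptyl would act alike alongside the fluoromethyl group of compound 2.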